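The source may hold more compounds than are shown below. What is called first, only, known or untested is meant among the compounds shown, and "the series" means these compounds.

Of the compounds shown here, two have so far been measured in a physicochemical assay for lipophilicity; on this read-out higher numbers stand for higher lipophilicity and lower numbers for lower lipophilicity. Compound 1 `CC(C)Sc1nnc(-c2c(CNc3nc4ccccc4[nH]3)c3ccccc3n2C)n1-c1ccccc1` gives 5.94, while compound 2 `CC(C)Sc1nnc(-c2c(CN3CCC(N4CCCC4)CC3)c3ccccc3n2C)n1-c1ccccc1` gives 5.16, the lower of the two numbers, and the step of a number 0.78 log units lower from compound 1 to compound 2 (beyond the scatter) is beyond the scatter. Compound 3 `COc1cccc(CNCc2c(-c3nnc(SC(C)C)n3-c3ccccc3)n(C)c3ccccc23)c1` has not yet been measured; it differs from compound 2 by (3-methoxybenzyl)amino in place of 4-(pyrrolidin-1-yl)piperidin-1-yl on a saturated chain carbon bound to an aromatic carbon. Among the compounds with values here, the single measured step changed the same place but brought in a different group, so it bears on this change only loosely. A modest rise is expected, a number 0.64 log units higher from compound 2 to compound 3 (beyond the scatter). For compound 3 the estimate in this assay is 5.8, ranging from 5.3 to 6.3.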

Compound 3, partition coefficient: 6.27
Beside the measured number, compound 3's estimate is 0.47 log units below it; the range from low to high includes it.
By their numbers in this assay, from the lowest: compound 2; then compound 1; then compound 3.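

At this position on a saturated chain carbon bound to an aromatic carbon, this assay moves in both directions, not only downward: (3-methoxybenzyl)amino in place of 4-(pyrrolidin-1-yl)piperidin-1-yl brings a number 1.11 log units higher from compound 2 to compound 3 (beyond the scatter) and is a larger step than the earlier one. With the amine nitrogen kept, 3-methoxybenzyl in place of 1H-benzimidazol-2-yl brings a number 0.33 log units higher from compound 1 to compound 3 (beyond the scatter) and puts compound 3 highest of the three. No measured evidence bears on these steps. Still open, from the compounds shown here alone, is where a plain benzyl group or a morpholin-4-yl group would fall on this scale.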